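The compounds below may be only part of what the source reports. "The series", "measured", "known", "first", "only" and "open" are said of these compounds alone.

Working notes on the caprolactam series in a functional assay on HeLa cells (Homo sapiens) for cytotoxicity, read by colorimetric assay and neutral red uptake, with a stated time of 72 h; on this read-out lower numbers stand for stronger inhibition and higher numbers for weaker inhibition. Compound 1 `CO[C@@H](C(=O)N[C@H]1CCCCNC1=O)[C@@H]1OC(C)(C)O[C@H](/C=C/C(C)(C)C)[C@@H]1O` carries the acetonide; in this assay compound 1 gives only a limit, > 150000 nM. Compound 2 `CO[C@@H](C(=O)N[C@H]1CC[C@@H](O)CNC1=O)[C@H](O)[C@@H](O)[C@H](O)/C=C/C(C)(C)C` is the triol with a 6-hydroxy-2-oxoazepan-3-yl amide, and in this assay compound 2 also reaches only a limit, > 150000 nM. For the measured compounds named here, compound 3 `CO[C@@H](C(=O)N[C@@H]1CCCCNC1=O)[C@H](O)[C@@H](O)[C@H](O)/C=C/C(C)(C)C` is the sole compound with a number: in this assay compound 3 gives 2100 nM. Going by the values given here, the single measured step, an at least 71-fold lower number from compound 2 to compound 3 (1.85 log units; beyond the scatter), removes the ring hydroxyl altogether; it rests on (the limit of > 150000 nM in this assay, at which 2 of the 3 values shown sit), so only its lower bound is known.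

Compound 4 `CO[C@@H](C(=O)N[C@@H]1CC[C@@H](O)CNC1=O)[C@H](O)[C@@H](O)[C@H](O)/C=C/C(C)(C)C` is now to be measured. It differs from compound 2 as follows: the two compounds have the same atoms and bonds and differ only in configuration as drawn: 1 of 7 stereo elements differ; a stereocentre at a saturated ring carbon is drawn S in compound 2 and R in compound 4. Among the compounds with values here, no measured step inverts this centre, so the step from compound 2 to compound 3 bears on it only in showing that the ring hydroxyl region governs the read-out. Since compound 2 sits at a limit, any number for compound 4 is a lower number; the size is open. Compound 4 is expected at 20000 nM, within 2000 nM to 150000 nM, which would mean an estimated step of an at least 7.5-fold lower number from compound 2 to compound 4 (0.87 log units; beyond the scatter).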

Compound 4, half-maximal inhibitory concentration: 15400 nM
The estimate for compound 4 lay 1.3-fold (0.11 log units) above the measured number, and the stated range covers the measured number.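

Inverting one stereocentre at a saturated ring carbon gives, in this assay, an at least 9.7-fold lower number from compound 2 to compound 4 (0.98 log units; beyond the scatter), so configuration alone moves the read-out in this pair: the fact that compounds 2 and 4 differ only in the configuration as drawn Compound 2 gives a limit and not a number, so this step has only a lower bound: the limit of > 150000 nM in this assay, at which 2 of the 4 values shown sit. Hydroxy in place of hydrogen on a saturated ring carbon now has a measured size, a 7.3-fold higher number from compound 3 to compound 4 (0.87 log units; beyond the scatter), where the earlier step gave only a bound.

As far as these compounds go, whether an amino or methoxy group in place of the ring hydroxy would read nearer compound 3 or compound 4 remains open. Also open, from the compounds shown here alone, is whether inverting the same stereocentre without the ring hydroxy would shift the read-out as it does in the hydroxylated pair.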